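Opening the imide side chain: compound 2 toward compound 4

A few compounds are considered here, and "the series" means these few. Any claim that something is new, unique, unknown or untested is made for them only; others in the source may bear on it.

Measured so far:
compound 1 `O=C(OCC1CCCN(CCCc2ccccc2)C1)c1ccccc1-c1ccccc1` — 13500 nM; 13500 nM (2 entries) in an in vitro functional assay on HEK ts201 cells for antagonist activity at Neuronal acetylcholine receptor; alpha4/beta2 (Homo sapiens), read by fluorescence and calcium flux; on this read-out higher numbers stand for weaker inhibition and lower numbers for stronger inhibition
compound 2 `COc1ccc(CC2CC(=O)N(c3ccccc3C(=O)OCC3CCCN(CCCc4ccccc4)C3)C2=O)cc1` — 38900 nM in this assay
compound 3 `O=C(NCc1ccccc1-c1ccccc1)C1CCCN(CCCc2ccccc2)C1` — 16600 nM in this assay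

Compound 1 was measured twice and gave the same value on both occasions. Among the single numbers available, compound 2 stands highest, that is weakest, in this assay; its nearest neighbour is compound 3, whose number is lower by a step that lies beyond the scatter, and compound 1 sits still lower. Among the measured compounds shown here, no two of the measured compounds differ in only one place, so no measured step can guide the next change directly.

Compound 4 `O=C(OCC1CCCN(CCCc2ccccc2)C1)c1ccccc1N1C(=O)CC(CCc2ccccc2)C1=O` differs from compound 2 in one place: benzyl in place of 4-methoxyphenyl on a saturated chain carbon bound to a saturated ring carbon. The same difference, cut one bond further out, reads 4-methoxybenzyl to phenethyl. For the measured compounds named here, because compound 2 gives 38900 nM and no measured pair isolates this kind of change, the step is expected to be small, and its direction cannot be fixed; the account expects it to stay within the scatter. Compound 4 is therefore estimated at 30000 nM in this assay, within 12000 nM to 80000 nM, which means an expected step of a 1.3-fold lower number from compound 2 to compound 4 (0.11 log units; within the scatter).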

Compound 4, half-maximal inhibitory concentration: 5130 nM
The estimate for compound 4 lay 5.8-fold (0.77 log units) above the measured number, and the stated range ends above it.
By their numbers in this assay, from the lowest: compound 4; then compound 3; then compound 2.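

In this assay, among the compounds shown here, this position on a saturated chain carbon bound to a saturated ring carbon proves sensitive to its substituent: benzyl in place of 4-methoxyphenyl gives a 7.6-fold lower number from compound 2 to compound 4 (0.88 log units; beyond the scatter), the first measured step between compounds that differ in one place. The pair changes two things at once, since the oxygen of the methoxy group goes and the same difference also reads 4-methoxybenzyl to phenethyl, so it cannot show which of the two matters. No measurement shown accounts for the step.

The compounds shown leave open whether a 4-methoxyphenethyl group, which keeps the methoxy group on the phenethyl chain, would stand with compound 2 or with compound 4. They also leave open how a longer chain, such as 3-phenylpropyl, would read at this position.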